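Replacing the Morpholine Sulfonamide with a Dimethylsulfamoyl Group

A few compounds are considered here, and "the series" means these few. Any claim that something is new, unique, unknown or untested is made for them only; others in the source may bear on it.

Compound 1 `CCOC(=O)[C@@H]1CCCN(S(=O)(=O)c2ccc(S(=O)(=O)N3CCOCC3)cc2)C1` stands weakest of the three compounds measured in a functional assay on BXPC-3 cells (Homo sapiens) for inhibition, read by MTT assay, with a stated time of 7 days; on this read-out lower numbers stand for stronger inhibition and higher numbers for weaker inhibition: compound 1 gives 23400 nM, the highest number of the set. Compound 2 `CCOC(=O)[C@@H]1CCCN(S(=O)(=O)c2ccc(S(=O)(=O)N(CC)CC)cc2C)C1` gives 5600 nM and compound 3 `CC(C)NS(=O)(=O)c1ccc(S(=O)(=O)N2CCC[C@@H](C(=O)N3CCN(c4nc(C(C)C)no4)CC3)C2)cc1` gives 2600 nM, both of them beyond the scatter from compound 1. Compound 4 `CCOC(=O)[C@@H]1CCCN(S(=O)(=O)c2ccc(S(=O)(=O)N(C)C)cc2)C1` differs from compound 1 in one place: dimethylamino in place of morpholin-4-yl on a sulfonyl sulfur. Compound 2 also differs from compound 1 at the sulfonyl sulfur, but in a second place as well, so its gap to compound 1 cannot be assigned to the amine alone. Among the compounds with values here, with no single-change step in hand, the expectation for compound 4 is a modest move toward a lower number, a 1.6-fold lower number from compound 1 to compound 4 (0.19 log units; within the scatter), possibly within the scatter. Compound 4 is estimated at 15000 nM, in the range 6000 nM to 40000 nM.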

Compound 4, half-maximal inhibitory concentration: 1000 nM
Compound 4: middle estimate off by 15-fold (1.18 log units), on the high side; measured number below the stated range.
By their numbers in this assay, from the lowest: compound 4; then compound 3; then compound 2; then compound 1.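

In this assay, within the data shown here, dimethylamino in place of morpholin-4-yl on a sulfonyl sulfur gives a 23-fold lower number from compound 1 to compound 4 (1.37 log units; beyond the scatter), the first single-change step in the set. It shows that, with the core of compound 1 otherwise unchanged, the read-out is highly sensitive to the amine at this position, which compound 2 could not show since it differs in a second place as well. Nothing available explains the size of this step.

The change removes both the ring and its oxygen, and the compounds shown do not separate the two. A piperidin-1-yl group on the same core, which keeps a ring but has no oxygen, would bear on that question.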